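Trimethoxyphenyl oxadiazoline: a trifluoromethylphenyl variant

The source may report more compounds than this note shows. Statements on the series, on what has been measured and on what is new or still open speak of the compounds shown alone.

Compound 1 `COc1cc(C2=NN(C(C)=O)C(c3ccccc3F)O2)cc(OC)c1OC`: 13.5%
Compound 2 `COc1cc(C(=O)N/N=C/c2ccc(Cl)c([N+](=O)[O-])c2)cc(OC)c1OC`: 32.1%
Compound 3 `COc1cc(/C=N/NC(=O)c2cc(OC)c(OC)c(OC)c2)cc(OC)c1OC`: 8.5%

In a functional assay on PC-3 cells (Homo sapiens) for antiproliferative activity, read by MTT assay, tested at 1 uM (a higher number here means a stronger effect of the compound at the concentration tested, a lower number a weaker effect), compound 1 gives 13.5%. Its number and that of compound 3 lie within the usual scatter of each other, so no order between them can be read. Compound 2 stands higher, beyond the scatter. Compound 4 `COc1cc(C2=NN(C(C)=O)C(c3cccc(C(F)(F)F)c3)O2)cc(OC)c1OC` differs from compound 1 in one place: 3-(trifluoromethyl)phenyl in place of 2-fluorophenyl on a saturated ring carbon. Going by the values given here, no measured pair shows this kind of change, so no step size can be drawn from the data. The change is expected to move the number of compound 4 in this assay by a step of a number 4.5 percentage points higher from compound 1 to compound 4 (within the scatter), a small rise that may not exceed the scatter. Compound 4 is therefore estimated at 18%, expected between 5% and 35%.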

Compound 4, a percentage reported as inhibition, at one concentration (the size of the read-out at that concentration, not a potency): 30.1%
Compound 4: middle estimate off by 12.1 percentage points, on the low side; measured number inside the range.
By their numbers in this assay, from the lowest: compounds 3 and 1 (each within the scatter of the next); then compounds 4 and 2 (each within the scatter of the next).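

Going by these compounds alone, on the shared core, the aryl group on the saturated ring carbon is the first place where a single change can be read in this assay: 3-(trifluoromethyl)phenyl in place of 2-fluorophenyl gives a modest step, a number 16.6 percentage points higher from compound 1 to compound 4 (beyond the scatter), beyond the usual scatter. Within the data shown here, the number at this position therefore responds to the aryl group it carries, which the earlier compounds, none differing in one place, could not show. Nothing at hand accounts for the step.

The compounds shown leave open whether the trifluoromethyl group itself or its place on the phenyl ring carries the step, and whether a nitrile or a methoxy group on that ring would move the number too.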